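Closing the Open Amine into a Ring

The compounds below may be only part of what the source reports. "The series", "measured", "known", "first", "only" and "open" are said of these compounds alone.

Measured so far:
Compound 1 `CN(C)CCCN(Cc1ccccc1)c1cccc(C(=O)N2CCc3ccc(OS(N)(=O)=O)cc3C2)c1` gives 26% in an assay on HEK293 cells for inhibition of Steryl-sulfatase (Homo sapiens), tested at 1 uM; a lower number here means a weaker effect, a higher number a stronger effect of the compound at the concentration tested.
Compound 2 `CCN(Cc1ccncc1)c1ccc(C(=O)N2CCc3ccc(OS(N)(=O)=O)cc3C2)cc1` gives 86.6% in this assay.
Compound 3 `CCN(Cc1ccc(F)cc1)c1cccc(C(=O)N2CCc3ccc(OS(N)(=O)=O)cc3C2)c1` gives 66.5% in this assay.

Compound 3 stands second highest of these three numbers. Its nearest neighbour is compound 2, whose number is higher by a margin beyond the usual scatter; its furthest is compound 1, whose number is lower, again beyond the scatter. All three share the same core, and they differ only in the amine-bearing group on the benzamide ring.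

Compound 4 `NS(=O)(=O)Oc1ccc2c(c1)CN(C(=O)c1cccc(N3CCc4ccccc4C3)c1)CC2` differs from compound 3 in one place: 1,2,3,4-tetrahydroisoquinolin-2-yl in place of ethyl(4-fluorobenzyl)amino on an aromatic carbon. The open amine with its ethyl and 4-fluorobenzyl arms is thus replaced by a ring-bound amine of nearly the same size, sitting at the same position, meta to a large group.

Among the compounds with values here, no two measured compounds differ in exactly one place, so there is no measured step to lean on. A step in this assay of modest size is expected, most likely downward from compound 3, but possibly none beyond the scatter. Compound 4 is estimated at 60%, with a range from 30% to 85%. The expected step is a number 6.5 percentage points lower from compound 3 to compound 4 (within the scatter).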

Compound 4, a percentage reported as inhibition, at one concentration (the size of the read-out at that concentration, not a potency): 50.2%
Estimate against measurement, compound 4: 9.8 percentage points above; low and high end bracket the measured number.
By their numbers in this assay, from the lowest: compound 1; then compound 4; then compound 3; then compound 2.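

Within the data shown here, this pair gives the first view of one change on its own, with everything else in the molecule held constant. In this assay, putting 1,2,3,4-tetrahydroisoquinolin-2-yl in place of ethyl(4-fluorobenzyl)amino on the aromatic carbon gives a number 16.3 percentage points lower from compound 3 to compound 4 (beyond the scatter), so this position responds to the change, although compound 4 still reaches 50.2% at the concentration tested. No measurement at hand explains this step.

The change closes the amine into a ring and removes the fluorine at the same time, and the compounds shown leave open which of the two accounts for the step. Also open, going by these compounds, is how a morpholine ring or a pyrrolidine ring at the same place would read out in this assay.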